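Trifluoromethyl in Place of Acetoxy on the Shared Core

The compounds below may be only part of what the source reports. "The series", "measured", "known", "first", "only" and "open" are said of these compounds alone.

Of the compounds shown here, three built on one core have been measured in a functional assay (trachea) with Rattus norvegicus as the target; a lower number here means a less potent compound, a higher number a more potent compound, by a factor of ten per unit of this negative logarithm. Compound 1 `CC1(C)C=C(n2ccccc2=O)c2cc(C(=O)c3ccccc3F)ccc2O1` gives 6.34. Compound 2 `CC1(C)C=C(n2ccccc2=O)c2cc(C=O)ccc2O1` gives 6.14, and the step of a number 0.20 log units lower from compound 1 to compound 2 (within the scatter) is small. Compound 3 `CC(=O)Oc1ccc2c(c1)C(n1ccccc1=O)=CC(C)(C)O2` gives 4.97, the lowest of the three numbers; its nearest neighbour is compound 2, reached through a number 1.17 log units lower from compound 2 to compound 3 (beyond the scatter), and compound 1 stands further away through a number 1.37 log units lower from compound 1 to compound 3 (beyond the scatter).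

Compound 4 `CC1(C)C=C(n2ccccc2=O)c2cc(C(F)(F)F)ccc2O1` is not yet measured. It differs from compound 3 in one place: trifluoromethyl in place of acetoxy on an aromatic carbon. The measured steps that bear on this change are the two that end at compound 3, in which acetoxy entered in place of formyl or of (2-fluorophenyl)carbonyl on the same aromatic carbon, and both were large drops. For the measured compounds named here, no measured compound carries trifluoromethyl on that carbon, so the size of the new step is uncertain, but taking acetoxy away again is expected to recover part of what those two steps lost. The estimated step is a number 0.83 log units higher from compound 3 to compound 4 (beyond the scatter), upward beyond the scatter. Compound 4 is expected to give 5.8, within a range from 5 to 6.6.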

Compound 4, logarithm of the reciprocal of the active concentration, log(1/C): 7.37
Estimate against measurement, compound 4: 1.57 log units below; the whole stated range lies below it.
By their numbers in this assay, from the lowest: compound 3; then compounds 2 and 1 (each within the scatter of the next); then compound 4.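

Before this result, the two highest numbers at this aromatic carbon belonged to formyl and (2-fluorophenyl)carbonyl, both of which attach to the ring through a carbonyl, so that carbonyl could have looked necessary. Compound 4 shows that it is not: within this assay trifluoromethyl, which has no carbonyl and is counted with 0 hydrogen-bond acceptors, stands above both groups, through a number 1.23 log units higher from compound 2 to compound 4 (beyond the scatter) and through a number 1.03 log units higher from compound 1 to compound 4 (beyond the scatter) on the shared core. Acetoxy and trifluoromethyl are each counted at 4 heavy atoms, yet the change between them brings a number 2.40 log units higher from compound 3 to compound 4 (beyond the scatter) and so the number at this position does not follow the heavy-atom count alone.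

Still open, from the compounds shown here alone, is how a nitrile, an amine, a carboxylic acid or a longer chain on this same aromatic carbon would compare with trifluoromethyl, and whether any of them would reach the number of compound 4. No measurement is available that accounts for the size of these steps.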